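The source may report more compounds than this note shows. Statements on the series, on what has been measured and on what is new or still open speak of the compounds shown alone.

Working notes on the dicyanopyrazine-fused series.

Compound 1 `CN(C)CCCCn1c(N)c(-c2nc3ccccc3n2C)c2nc(C#N)c(C#N)nc21` is the reference point. In a functional assay on cells (Homo sapiens) for antiproliferative activity, read by MTT assay, with a stated time of 48 h (a lower number here means a stronger inhibitor, a higher number a weaker inhibitor), compound 1 gives 1790 nM. Compound 2 `CCN(CC)CCCCn1c(N)c(-c2nc3ccccc3n2C)c2nc(C#N)c(C#N)nc21` carries one change relative to compound 1, namely (diethylamino in place of dimethylamino on a saturated chain carbon, four bonds along the chain from an aromatic nitrogen), and in this assay compound 2 gives 2890 nM. The step of a 1.6-fold higher number from compound 1 to compound 2 (0.21 log units; within the scatter) is within the scatter, so the two compounds cannot be ordered against each other on this read-out.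

Compound 3 `CN(C)CCCn1c(N)c(-c2nc3cc(Cl)ccc3[nH]2)c2nc(C#N)c(C#N)nc21` belongs to a different core; the difference between the core of compound 3 and the core of compound 1 is not broken down here. In this assay compound 3 gives 28100 nM, the highest number of the three measured compounds, beyond the scatter against both compound 1 and compound 2, so compound 3 is the weakest inhibitor measured so far.

Compound 4 `CCN(CC)CCCn1c(N)c(-c2nc3cc(Cl)ccc3[nH]2)c2nc(C#N)c(C#N)nc21` is not yet measured. Its relation to compound 3 is diethylamino in place of dimethylamino on a saturated chain carbon, three bonds along the chain from an aromatic nitrogen. This is the same kind of change as that from compound 1 to compound 2, but not the same: there the place was on a saturated chain carbon four bonds along the chain from an aromatic nitrogen, here it is three bonds along the chain from an aromatic nitrogen, and the core differs as well. For the measured compounds named here, the only guide is the measured step of a 1.6-fold higher number from compound 1 to compound 2 (0.21 log units; within the scatter), which lay within the scatter. On that basis the step of a 1.4-fold higher number from compound 3 to compound 4 (0.15 log units; within the scatter) is expected to be small, with a slight lean toward a higher number because compound 1 to compound 2 gave a 1.6-fold higher number from compound 1 to compound 2 (0.21 log units; within the scatter). Compound 4 is accordingly estimated at 40000 nM in this assay, with an expected range from 16000 nM to 100000 nM.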

Compound 4, half-maximal inhibitory concentration: 23200 nM
Estimate against measurement, compound 4: 1.7-fold (0.24 log units) above, within the range that was stated.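

In this assay, diethylamino in place of dimethylamino on the chain of compound 3 gives a 1.2-fold lower number from compound 3 to compound 4 (0.08 log units; within the scatter), so this pair cannot be ordered on this read-out. Set beside the earlier step, the change shows no difference that can be told apart between the two cores: the same change on two cores in this assay, a 1.6-fold higher number (0.21 log units; within the scatter) from compound 1 to compound 2 and a 1.2-fold lower number (0.08 log units; within the scatter) from compound 3 to compound 4, 2.0-fold (0.29 log units) apart, within the scatter of two such steps. This shows that, in these two pairs, the exchange left the number within the scatter on both cores; it does not show that the step is identical on the two cores or fix a direction for it, and it cannot separate core from chain, as the change sits three bonds along the chain from an aromatic nitrogen in one pair and four bonds along in the other.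

Still open, going by these compounds, is how the core and the chain each bear on the result, which would take a pair differing in chain length alone, such as a butyl chain on the core of compound 3. Also open, on these data alone, is whether the flat response extends to amines further from these two, such as pyrrolidine, piperidine or morpholine in place of the diethylamino group.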